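The source may hold more compounds than are shown below. What is called first, only, known or untested is meant among the compounds shown, and "the series" means these compounds.

In a functional assay on B16-F10 cells (Mus musculus) for antiproliferative activity, read by MTT assay, with a stated time of 48 h (a lower number here means a stronger inhibitor, a higher number a weaker inhibitor), compound 1 `CC(=O)N1N=C(c2ccc3ccccc3c2)OC1c1ccccc1`, which bears no bromo group, gives 2.57 ug/mL. Its bromo analogue, compound 2 `CC(=O)N1N=C(c2ccc3ccccc3c2)OC1c1ccccc1Br`, gives 6.98 ug/mL, the higher of the two numbers, which makes it the weaker inhibitor of the pair. Going by the values given here, the only measured step is modest but beyond the scatter: a 2.7-fold higher number from compound 1 to compound 2 (0.43 log units; beyond the scatter), with bromo in place of hydrogen on an aromatic carbon.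

The next compound, compound 3 `CC(=O)N1N=C(c2ccc3ccccc3c2)OC1c1cccc(Br)c1`, has the same atoms as compound 2, joined differently: 3-bromophenyl in place of 2-bromophenyl on a saturated ring carbon. The change is 3-bromophenyl in place of 2-bromophenyl on a saturated ring carbon. Among the compounds with values here, no measured pair shows what moving the bromo group does, so the one step above sets only a rough scale. Compound 3 still carries bromo, yet the value of compound 1 at 2.57 ug/mL suggests a mild lean towards a lower number. The expected change is small, a 1.6-fold lower number from compound 2 to compound 3 (0.19 log units; within the scatter), and no clear step beyond the scatter is anticipated. Compound 3 is estimated at 4.5 ug/mL, with an expected range of 2 ug/mL to 10 ug/mL.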

Compound 3, half-maximal inhibitory concentration: 2.36 ug/mL
Beside the measured number, compound 3's estimate is 1.9-fold (0.28 log units) above it; the range from low to high includes it.
By their numbers in this assay, from the lowest: compounds 3 and 1 (each within the scatter of the next); then compound 2.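

In this assay, moving the bromo group is a step in its own right: 3-bromophenyl in place of 2-bromophenyl on the saturated ring carbon gives a 3.0-fold lower number from compound 2 to compound 3 (0.47 log units; beyond the scatter), so in this pair the outcome depends on where the bromo group sits on the phenyl ring and not only on its presence. Bromo in place of hydrogen on an aromatic carbon therefore has no single reading, as the 3-bromophenyl compound gives a 1.1-fold lower number from compound 1 to compound 3 (0.04 log units; within the scatter), while the 2-bromophenyl compound gave a 2.7-fold higher number from compound 1 to compound 2 (0.43 log units; beyond the scatter). No measurement available here explains why the two bromo isomers part in this way.

The compounds shown leave open whether this dependence on place belongs to bromo alone, or whether a chloro or a methoxy group in place of bromo would follow the same course. They also do not tell what a longer chain in place of the acetyl group, or an amine on the phenyl ring, would do to the number in this assay.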